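Dimethylthiophene change carried from one core to another

The compounds below may be only part of what the source reports. "The series", "measured", "known", "first", "only" and "open" are said of these compounds alone.

Compound 1 `N=C(N)N/N=C/c1c(-c2ccsc2)nc2sccn12` gives 17400 nM in a functional assay on cells (Cancer cell lines, Homo sapiens) for inhibition; a lower number here means a stronger inhibitor of growth, a higher number a weaker inhibitor of growth. Compound 2 `Cc1cc(-c2nc3sccn3c2/C=N/NC(=N)N)c(C)s1` carries 2,5-dimethylthiophen-3-yl in place of thiophen-3-yl on an aromatic carbon and in this assay compound 2 gives 16200 nM; the step is a 1.1-fold lower number from compound 1 to compound 2 (0.03 log units; within the scatter). Compound 3 `N=C(N)N/N=C/c1c(-c2ccsc2)nc2n1CCS2` rests on another core; the difference between the two cores is not broken down here. In this assay compound 3 gives 32400 nM, within the scatter of compound 1 and of compound 2. Compound 4 `Cc1cc(-c2nc3n(c2/C=N/NC(=N)N)CCS3)c(C)s1` is not yet measured and carries the same kind of change, (2,5-dimethylthiophen-3-yl in place of thiophen-3-yl on an aromatic carbon); here the place is also two ring bonds from two ring atoms that each bear a fused ring. Because a 1.1-fold lower number from compound 1 to compound 2 (0.03 log units; within the scatter) lay within the scatter, a small step is expected again. For compound 4 the expected step is a 1.1-fold lower number from compound 3 to compound 4 (0.03 log units; within the scatter). Compound 4 is thus estimated at 30000 nM, with a range from 12000 nM to 75000 nM.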

Compound 4, concentration for 50% growth inhibition: 24000 nM
The estimate for compound 4 lay 1.3-fold (0.10 log units) above the measured number; the range from low to high includes it.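

In this assay, 2,5-dimethylthiophen-3-yl in place of thiophen-3-yl gives a 1.4-fold lower number from compound 3 to compound 4 (0.13 log units; within the scatter), again a small step on the second core. The two steps do not differ, so within these four compounds the change carries from one core to the other: the same change on two cores in this assay, a 1.1-fold lower number (0.03 log units; within the scatter) from compound 1 to compound 2 and a 1.4-fold lower number (0.13 log units; within the scatter) from compound 3 to compound 4, 1.3-fold (0.10 log units) apart, within the scatter of two such steps. This agreement rests on two steps that both lie within the scatter, so it does not show that a larger step would carry over in the same way.

Going by these compounds, it remains open whether an amine or a carboxylic acid on the same aromatic carbon, in place of 2,5-dimethylthiophen-3-yl, would give a step beyond the scatter. On these data alone, it also remains open whether such a step would match on both cores.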